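This account rests on a few compounds, and the source may have more. Where it says the series, first, only, none or still open, it means among the compounds named here.

Measured so far:
- compound 1 `CCCCNc1nc(N)nc2c1CNCC2`: 7.2 uM
- compound 2 `CCCCNc1nc(N)nc2c1CN(Cc1ccc(OC)cc1)CC2`: 0.08 uM

In an assay on HEK293 cells for agonist activity at Toll-like receptor 8 (Homo sapiens), read by a luciferase reporter, with a stated time of 6 h (a higher number here means that more compound is needed for the effect, a lower number that less compound is needed), compound 1 gives 7.2 uM, while compound 2 gives 0.08 uM. Compound 2 thus has the lowest of the two numbers, and the gap to compound 1 lies beyond the scatter, so compound 2 needs clearly less material for the effect. Compound 3 `CCCCNc1nc(N)nc2c1CN(Cc1cccnc1)CC2` has not been measured in this assay. It differs from compound 2 in one place: pyridin-3-yl in place of 4-methoxyphenyl on a saturated chain carbon bound to an amine nitrogen in a ring. Within the data shown here, only two measurements exist, and no pair of them isolates this change, so the effect of the new group rests on judgment alone. A modest rise in the number is expected from compound 2 to compound 3, as given by a 3.1-fold higher number from compound 2 to compound 3 (0.49 log units; beyond the scatter), but not one that returns to the level of compound 1. For compound 3 the expected value in this assay is 0.25 uM, with a range from 0.06 uM to 1 uM.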

Compound 3, minimum effective concentration: 0.13 uM
For compound 3 the middle estimate is 1.9-fold (0.28 log units) above the measured one, within the range that was stated.
By their numbers in this assay, from the lowest: compounds 2 and 3 (each within the scatter of the next); then compound 1.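

In this assay the change from 4-methoxyphenyl to pyridin-3-yl gives a 1.6-fold higher number from compound 2 to compound 3 (0.21 log units; within the scatter) and so the two groups cannot be told apart here, even though the new ring holds a hetero atom and the group has fewer heavy atoms. Placing (pyridin-3-yl)methyl on the amine nitrogen in the ring gives a 55-fold lower number from compound 1 to compound 3 (1.74 log units; beyond the scatter) and this shows that the large gain over hydrogen at this position does not depend on the 4-methoxyphenyl group alone. No measurement offered here explains either step.

As far as these compounds go, it remains open whether this position needs an aromatic ring at all, since a cyclohexyl ring or a plain methyl group on the same nitrogen could behave quite differently. From the compounds shown here alone, the effect of a carboxylic acid or an amine on the ring also remains unknown.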